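Working notes: side-chain change from compound 3 to compound 4

The source may report more compounds than this note shows. Statements on the series, on what has been measured and on what is new or still open speak of the compounds shown alone.

Three measured compounds share one core and differ only in the group attached to it. Compound 1 `Nc1ccc(Nc2c(C(=O)NCc3ccc(F)cc3)nc(Br)c3cccnc23)cc1` gives 7000 nM in a functional assay on MDA-MB-435 cells (Homo sapiens) for cytotoxicity, read by MTT assay, with a stated time of 72 h; a lower number here means a stronger inhibitor, a higher number a weaker inhibitor. Compound 2 `O=C(NCc1ccc(F)cc1)c1nc(Br)c2cccnc2c1N1CCNCC1` gives 8000 nM in this assay. Compound 3 `NCCCCCCNc1c(C(=O)NCc2ccc(F)cc2)nc(Br)c2cccnc12` gives 6000 nM in this assay.

Among the compounds with values here, the three numbers lie together: a 1.1-fold higher number from compound 1 to compound 2 (0.06 log units; within the scatter), a 1.2-fold lower number from compound 1 to compound 3 (0.07 log units; within the scatter) and a 1.3-fold lower number from compound 2 to compound 3 (0.12 log units; within the scatter) are all within the scatter, so compound 3 separates from neither compound 1 nor compound 2 in this assay, and no compound can be called the stronger or weaker one on these data.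

Compound 4 `CN(C)CCCNc1c(C(=O)NCc2ccc(F)cc2)nc(Br)c2cccnc12` differs from compound 3 by dimethylamino in place of 3-aminopropyl on a saturated chain carbon, three bonds along the chain from a nitrogen on an aromatic ring. The measured steps that bear on this are the two that exchange the whole group on the core while keeping the rest unchanged, a 1.2-fold lower number from compound 1 to compound 3 (0.07 log units; within the scatter) and a 1.3-fold lower number from compound 2 to compound 3 (0.12 log units; within the scatter); both are within the scatter. Within the data shown here, no measured pair tests the exchange of a chain amine for dimethylamino itself. Going by these compounds, on that basis no step beyond the scatter is expected in this assay, in either direction, though the range is kept wide since the change is untested. Compound 4 is expected to give 6000 nM in this assay, with a range from 2500 nM to 15000 nM. This corresponds to an expected step of no change at the digits printed from compound 3 to compound 4 (within the scatter).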

Compound 4, half-maximal inhibitory concentration: 7000 nM
Beside the measured number, compound 4's estimate is 1.2-fold (0.07 log units) below it, within the range that was stated.
By their numbers in this assay, from the lowest: compounds 3, 1, 4 and 2 (each within the scatter of the next).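

In this assay, dimethylamino in place of 3-aminopropyl on a saturated chain carbon, three bonds along the chain from a nitrogen on an aromatic ring, gives a 1.2-fold higher number from compound 3 to compound 4 (0.07 log units; within the scatter), so this place accepts an exchange in which the entering group has 0 hydrogen-bond donors and the leaving group has 1 without a step beyond the scatter. The group as a whole also fails to separate from the two other groups on the shared core, with a 1.1-fold lower number from compound 2 to compound 4 (0.06 log units; within the scatter) for (3-(dimethylamino)propyl)amino in place of piperazin-1-yl and no change at the digits printed from compound 1 to compound 4 (within the scatter) for 3-(dimethylamino)propyl in place of 4-aminophenyl. No measurement is at hand that would account for these values lying together.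

Going by these compounds, it remains open whether a chain end without an amine, such as a carboxylic acid or a hydroxyl, would give a step beyond the scatter at this place. On these data alone, it is equally open whether a longer chain ending in dimethylamino, or a dimethylamino end carried on the 6-aminohexyl length, would separate from compound 4 in this assay.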